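Methyl Replaces Hydrogen: Expected Cytotoxicity of Compound 3

This account rests on a few compounds, and the source may have more. Where it says the series, first, only, none or still open, it means among the compounds named here.

Two measured compounds share one core. Compound 1 `CC(C)=CCOc1cc(Nc2nccc(N)n2)ccc1Cl` carries an amino group on the ring, and in an ADME assay on MT2 cells (Homo sapiens) for cytotoxicity (a lower number here means that less compound is tolerated, a higher number that more compound is tolerated), compound 1 gives 500 nM. Compound 2 `CC(C)=CCOc1cc(Nc2ncccn2)ccc1Cl` lacks that group; in this assay compound 2 gives 2500 nM, the highest of the two numbers. For the measured compounds named here, the only step measured so far, a 5.0-fold higher number from compound 1 to compound 2 (0.70 log units; beyond the scatter), shows that hydrogen in place of amino on an aromatic carbon lets the cells tolerate more compound.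

Compound 3 `CC(C)=CCOc1cc(Nc2nccc(C)n2)ccc1Cl` is compound 2 with methyl in place of hydrogen on an aromatic carbon. Put another way, pyrimidin-2-yl becomes 4-methylpyrimidin-2-yl. Going by the values given here, no measured step involves a methyl, so any comparison is indirect: the one step known, a 5.0-fold higher number from compound 1 to compound 2 (0.70 log units; beyond the scatter), concerns an amino group, which is not a methyl, and the entering methyl brings no hydrogen-bond donors or acceptors. The expectation is therefore a small shift downward, near or within the scatter, a 1.3-fold lower number from compound 2 to compound 3 (0.10 log units; within the scatter). Compound 3 is estimated to give 2000 nM in this assay, with an expected range from 800 nM to 5000 nM.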

Compound 3, half-maximal cytotoxic concentration: 150 nM
Beside the measured number, compound 3's estimate is 13-fold (1.12 log units) above it; measured number outside the range, below it.
By their numbers in this assay, from the lowest: compound 3; then compound 1; then compound 2.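

This position on the ring turns out to be far more sensitive than the amino group alone suggested. In this assay, adding a single methyl gives a 17-fold lower number from compound 2 to compound 3 (1.22 log units; beyond the scatter), a large step that exceeds the modest one seen earlier with the amino group, so even the smallest carbon group can change how much compound the cells tolerate. Exchanging one substituent for the other at this same place gives a 3.3-fold lower number from compound 1 to compound 3 (0.52 log units; beyond the scatter), which means that both amino and methyl leave the number below that of hydrogen, with methyl the lower of the two, and that the effect does not depend on the amino group. No measurement available here explains why the methyl has this effect.

The three compounds leave open whether the trend continues with a larger carbon group, such as an ethyl or a longer chain, or changes with a methoxy group or a carboxylic acid at this place. They also leave open whether a methyl elsewhere on the same ring would give a step of similar size, since only this one place has been compared.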